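This account rests on a few compounds, and the source may have more. Where it says the series, first, only, none or still open, it means among the compounds named here.

Compound 2 `COC[C@H]1C[C@@](CC(C)C)(C(=O)O)N(C(=O)c2ccc(C(C)(C)C)c(OC)c2)[C@H]1COC(C)=O` stands, in an ADME assay on Huh-5-2 cells (Homo sapiens) for cytotoxicity, with a stated time of 3 days (on this read-out lower numbers stand for higher toxicity in this test and higher numbers for lower toxicity in this test), at > 120000 nM, which is a limit of the assay rather than a measured number. Compound 1 `COC[C@H]1C[C@@](CC(C)C)(C(=O)O)N(C(=O)c2ccc(C(C)(C)C)c(OC)c2)[C@H]1[C@H]1COC(=O)O1` gives in this assay > 120000 nM, again a limit. Going by the values given here, the step from compound 1 to compound 2 a step that the two limits leave unreadable from compound 1 to compound 2 is therefore not readable in size, and the only evidence on the measured compounds is the limit of > 120000 nM in this assay, at which 2 of the 2 values shown sit.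

Compound 3 `C=CCOC[C@H]1[C@@H](COC)C[C@@](CC(C)C)(C(=O)O)N1C(=O)c1ccc(C(C)(C)C)c(OC)c1` differs from compound 2 by allyl in place of acetyl on an oxygen on a saturated carbon. Among the compounds with values here, only the pair of compound 1 and compound 2 bears on this change, and its step is hidden behind the two limits; neither value in this assay rose above the ceiling of what could be measured. Compound 3 is therefore expected to show no step beyond the scatter, a step that the limit leaves unreadable from compound 2 to compound 3, and most likely to sit again at a limit. The estimate for compound 3 in this assay is 150000 nM, with a range from 50000 nM to 500000 nM.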

Compound 3, half-maximal cytotoxic concentration: > 120000 nM
Compound 3: only a limit was reported; the forecaster's own chance of this, stated with the estimate: 85%; the middle value does not contradict the limit.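

In this assay compound 3 gives > 120000 nM, which is a limit of the assay. Going by these compounds alone, no step from compound 1 or compound 2 to compound 3 can be read. The compounds shown leave open the actual cytotoxic concentrations of compound 1, compound 2 and compound 3, and whether these changes alter them at all: the limit of > 120000 nM in this assay, at which 3 of the 3 values shown sit.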